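The compounds below may be only part of what the source reports. "The series", "measured", "known", "first", "only" and "open" are said of these compounds alone.

Of the compounds shown here, three have been tested so far in a functional assay on the whole organism for antagonist activity, with Mus musculus as the target; a lower number here means that less compound is needed, a higher number that more compound is needed for the effect: compound 1 (`CC(=O)N(C)CC#CCn1ccnc1`), compound 2 (`CCOC(=O)N(C)CC#CCN1CCCC1`) and compound 3 (`O=C1NCCN1CC#CCn1ccnc1`). Compound 1 gives > 100 mg/kg, which is a limit of the assay and not a number. Compound 2 gives > 100 mg/kg, again a limit. Compound 3, the starting point here, gives > 100 mg/kg, also only a limit. For the measured compounds named here, the whole record so far is therefore (the limit of > 100 mg/kg in this assay, at which 3 of the 3 values shown sit), and no two tested compounds differ in just one place, so there is no measured step to serve as a guide.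

Compound 4 (`Cc1cncn1CC#CCN1CCNC1=O`) differs from compound 3 by one small edit: methyl in place of hydrogen on an aromatic carbon. No step beyond the scatter is expected, in either direction, and the estimated step is a step that the limit leaves unreadable from compound 3 to compound 4. This expectation rests on compound 3, whose > 100 mg/kg is a limit. For compound 4 the estimate in this assay is 120 mg/kg, with an expected range from 40 mg/kg to 300 mg/kg.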

Compound 4, dose for half-maximal effect: 21 mg/kg
Beside the measured number, compound 4's estimate is 5.7-fold (0.76 log units) above it; measured number below the stated range.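

In this assay, methyl in place of hydrogen on an aromatic carbon gives an at least 4.7-fold lower number from compound 3 to compound 4 (0.67 log units; beyond the scatter). This shows that a single added methyl, on the ring carbon next to the ring atom that bears a large group, is enough to bring a compound off the limit and give a readable dose, which the other compounds could not show. That step is only a minimum, because the starting value is itself a limit: the limit of > 100 mg/kg in this assay, at which 3 of the 4 values shown sit.

The compounds shown leave open whether methyl is special here, or whether ethyl or chlorine on this same carbon would serve as well or better. They also leave open whether methyl on the other aromatic carbons of this ring would have a similar effect, and whether the same edit would help on the core of compound 1.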